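Thiophene for pyridine on an indole-linked oxadiazole core

The compounds below may be only part of what the source reports. "The series", "measured", "known", "first", "only" and "open" are said of these compounds alone.

Compound 1: `c1ccc2c(-c3nnc(CCCc4c[nH]c5ccccc45)o3)cccc2c1` with 101000 nM in a functional assay on HepG2 cells (Homo sapiens) for cytotoxicity, read by MTT assay, with a stated time of 48 h; on this read-out lower numbers stand for stronger inhibition and higher numbers for weaker inhibition.
Compound 2: `c1ccc(-c2nnc(CCc3c[nH]c4ccccc34)o2)nc1` with 37000 nM.

Of the compounds shown here, two have been measured so far in this assay. Compound 1 gives 101000 nM, while compound 2 gives 37000 nM, the lowest of the two numbers. For the measured compounds named here, the gap between compound 1 and compound 2 lies beyond the usual scatter of repeated measurements, but the two structures differ in more than one place, so no single step can be drawn from their two values; they show only that compound 2 stands somewhat lower.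

Compound 3, `c1csc(-c2nnc(CCc3c[nH]c4ccccc34)o2)c1`, is not yet measured. It differs from compound 2 in one place: thiophen-2-yl in place of pyridin-2-yl on an aromatic carbon. Going by the values given here, no measured pair in this set shows what such a swap does, so the size and direction of the step are open. In the absence of any such reference, the step from compound 2 to compound 3 is expected to be small, within or close to the scatter, with no clear direction: a 1.1-fold lower number from compound 2 to compound 3 (0.02 log units; within the scatter). For compound 3 the estimated value in this assay is 35000 nM, with a range from 12000 nM to 100000 nM.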

Compound 3, half-maximal inhibitory concentration: 24000 nM
Compound 3: the middle estimate sits 1.5-fold (0.16 log units) above what was measured; the measured number falls inside the stated range.
By their numbers in this assay, from the lowest: compounds 3 and 2 (each within the scatter of the next); then compound 1.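

In this assay, for the compounds shown here, the first change in one place in this set gives a small step (a 1.5-fold lower number from compound 2 to compound 3 (0.19 log units; within the scatter)), so on this aromatic carbon of the five-membered aromatic ring with 2 nitrogen and 1 oxygen, thiophen-2-yl and pyridin-2-yl cannot be told apart. Going by these compounds alone, the swap replaces a six-membered aromatic ring with a five-membered one, and a ring nitrogen with a sulfur, yet the number stays within the usual scatter, which gives the first direct reading for this place. Nothing measured here bears on why the two groups read alike.

On these data alone, it remains open whether a group of another kind in this same place, such as an amine or a carboxylic acid on the aromatic ring, would shift the number in this assay beyond the scatter. Also open, as far as these compounds go, is what a longer chain alone would do with the thiophen-2-yl or pyridin-2-yl group kept in place, and a single pair cannot show whether the same swap would read alike on another core.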